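Changing the sulfur chain of compound 2

The source may hold more compounds than are shown below. What is called first, only, known or untested is meant among the compounds shown, and "the series" means these compounds.

In a functional assay on HepG2 cells (Homo sapiens) for inhibition, read by MTT assay, with a stated time of 48 h (a higher number here means a weaker inhibitor, a lower number a stronger inhibitor), compound 1 (`CCSc1nnc(-c2cc(OC)c(OC)c(OC)c2)n1-c1ccc(OC)cc1`) gives > 60000 nM, which is a limit and not a number. Compound 2 (`CCSc1nnc(-c2cc(OC)c(OC)c(OC)c2)n1-c1ccc(N(C)C)cc1`) gives > 60000 nM, which is also a limit. Exchanging methoxy for dimethylamino is a step that the two limits leave unreadable from compound 1 to compound 2, and both compounds rest at the limit of > 60000 nM in this assay, at which 2 of the 2 values shown sit. Compound 2 therefore stands at the limit, with no measured number to start from.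

Compound 3 (`COc1ccc(C(=O)CSc2nnc(-c3cc(OC)c(OC)c(OC)c3)n2-c2ccc(N(C)C)cc2)cc1O`) keeps the dimethylamino group and changes the chain on sulfur: (3-hydroxy-4-methoxyphenyl)carbonyl in place of methyl on a saturated chain carbon bound to a sulfur. Cut one bond further out, this reads ethyl to ((3-hydroxy-4-methoxyphenyl)carbonyl)methyl. For the measured compounds named here, the one measured step concerns a different group and has no readable size, so it sets no size for this change. Any readable number in this assay would mean stronger inhibition because compound 2 rests at the limit of > 60000 nM. A clear move in that direction is expected, though its size remains a broad judgement based on the scale of the structural change. The expected move is an at least 20-fold lower number from compound 2 to compound 3 (1.30 log units; beyond the scatter). For compound 3, the estimated value is 3000 nM, with an expected range from 200 nM to 40000 nM.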

Compound 3, half-maximal inhibitory concentration: > 100000 nM
Compound 3 ended at the assay's limit (the forecaster's own chance of this, stated with the estimate: 20%); middle value at least 33-fold (1.52 log units) from the limit.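

In this assay compound 3 gives > 100000 nM, which is a limit and not a number. Compound 2 also stands at a limit, so the step to compound 3 cannot be read. The compounds shown leave open whether any change to the chain on sulfur can bring a readable number in this assay.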